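Sulfonyl substituent variation in the bicyclic sulfonamide acid series

The compounds below may be only part of what the source reports. "The series", "measured", "known", "first", "only" and "open" are said of these compounds alone.

Compound 1 `CCc1ccc(S(=O)(=O)N[C@H]2C3CC[C@H](C3)[C@@H]2C/C=C\CCCC(=O)O)cc1` gives the lowest of the three numbers measured in a functional assay (thoracic aorta) for inhibition, with Rattus norvegicus as the target; a lower number here means a stronger inhibitor, a higher number a weaker inhibitor: compound 1 gives 1.5 nM. Compound 2 `Cc1ccccc1S(=O)(=O)N[C@H]1C2CC[C@H](C2)[C@@H]1C/C=C\CCCC(=O)O` carries 2-methylphenyl on the sulfonyl sulfur, and in this assay compound 2 gives 3.7 nM, so that a 2.5-fold higher number from compound 1 to compound 2 (0.39 log units; beyond the scatter). Compound 3 `CS(=O)(=O)N[C@H]1C2CC[C@H](C2)[C@@H]1C/C=C\CCCC(=O)O` carries only methyl there, and in this assay compound 3 gives 1580 nM; accordingly a 1100-fold higher number from compound 1 to compound 3 (3.02 log units; beyond the scatter) and a 430-fold higher number from compound 2 to compound 3 (2.63 log units; beyond the scatter). The two aryl-bearing compounds lie close to each other, while the methyl compound stands far from both.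

Compound 4 `O=C(O)CCC/C=C\C[C@H]1[C@@H]2CCC(C2)[C@@H]1NS(=O)(=O)Cc1ccccc1` is not yet measured. Its difference from compound 1 is benzyl in place of 4-ethylphenyl on a sulfonyl sulfur. Among the measured compounds shown here, the steps that bear on this are a 1100-fold higher number from compound 1 to compound 3 (3.02 log units; beyond the scatter), where the aromatic ring is lost altogether, and a 2.5-fold higher number from compound 1 to compound 2 (0.39 log units; beyond the scatter), where an aromatic ring stays on the sulfonyl sulfur. For the measured compounds named here, compound 4 keeps one six-membered aromatic ring, but the ring is no longer directly on the sulfonyl sulfur; no measured compound covers this case. A step toward a higher number is therefore expected, larger than the modest aryl-to-aryl step yet well short of the large aryl-to-methyl step. For compound 4 the expected value in this assay is 20 nM, with a range from 3 nM to 150 nM. This corresponds to an expected step of a 13-fold higher number from compound 1 to compound 4 (1.12 log units; beyond the scatter).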

Compound 4, half-maximal inhibitory concentration: 111 nM
Compound 4: the middle estimate sits 5.6-fold (0.74 log units) below what was measured; low and high end bracket the measured number.
By their numbers in this assay, from the lowest: compound 1; then compound 2; then compound 4; then compound 3.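

In this assay, keeping a six-membered aromatic ring is not enough to hold the number low: benzyl on the sulfonyl sulfur gives a 74-fold higher number from compound 1 to compound 4 (1.87 log units; beyond the scatter) and a 30-fold higher number from compound 2 to compound 4 (1.48 log units; beyond the scatter), both large, although benzyl and 4-ethylphenyl each carry one six-membered aromatic ring of carbon only and neither has hydrogen-bond donors or acceptors. The ring still has some effect in the benzyl setting, as phenyl in place of hydrogen on the saturated chain carbon bound to the sulfonyl sulfur gives a 14-fold lower number from compound 3 to compound 4 (1.15 log units; beyond the scatter), so among these four compounds the lowest numbers belong to the two with the aromatic ring on the sulfonyl sulfur itself, compound 4 falls well above them, and compound 3 stands highest. Nothing available explains the loss from the aryl compounds to the benzyl compound.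

Still open, as far as these compounds go, is whether 2-phenylethyl, with a longer chain from the sulfonyl sulfur to the ring, would continue this trend or reverse it. From the compounds shown here alone, it is equally open whether 4-ethylbenzyl would recover any of the ground lost, which would show whether the 4-ethyl group can act independently of the ring's attachment to the sulfonyl sulfur.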